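This account rests on a few compounds, and the source may have more. Where it says the series, first, only, none or still open, it means among the compounds named here.

Measured compounds:
- compound 1, `O=C(O[C@H]1C[C@H](n2cc(F)c(=O)[nH]c2=O)O[C@@H]1COP(=O)(O)Oc1ccccc1)c1ccccc1`: 5.1 h
- compound 2, `CCOC(=O)C[n+]1cccc2cc(OP(=O)([O-])OC[C@H]3O[C@@H](n4cc(F)c(=O)[nH]c4=O)C[C@@H]3OC(=O)c3ccccc3)ccc21`: 5.9 h

Of the compounds shown here, two have been measured in an ADME assay on a cell-free system (serum, Homo sapiens) for metabolic stability, read by HPLC, tested at 2 mM; on this read-out higher numbers stand for a longer-lived compound and lower numbers for a shorter-lived compound. Compound 1 gives 5.1 h, which is the lower of the two numbers, while compound 2 gives 5.9 h; the gap between them is within the usual scatter of this assay, so the two compounds cannot be told apart on this read-out.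

The step of interest leads from compound 1 to the unmeasured compound 3, `C[N+]1(C)CCC(OP(=O)([O-])OC[C@H]2O[C@@H](n3cc(F)c(=O)[nH]c3=O)C[C@@H]2OC(=O)c2ccccc2)CC1`. The change is a group of 12 heavy atoms (7 carbon, 1 nitrogen, 3 oxygen, 1 phosphorus; one six-membered non-aromatic ring with 1 hetero atom) in place of a group of 10 heavy atoms (6 carbon, 3 oxygen, 1 phosphorus; one six-membered aromatic ring of carbon only), on an oxygen on a saturated carbon. For the measured compounds named here, no step between two measured compounds is available for this change, so there is nothing in the measured data that would point either way. Compound 2, which also carries a different group at this oxygen, gives a value in this assay within the scatter of compound 1. On that ground the step of a 1.1-fold higher number from compound 1 to compound 3 (0.03 log units; within the scatter) is expected to be small, not beyond the scatter in either direction. Compound 3 is therefore estimated to give 5.5 h in this assay, within a range from 3 h to 10 h.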

Compound 3, half-life in the Homo sapiens assay: > 120 h
Compound 3 gave a limit, no number (the forecaster's own chance of this, stated with the estimate: 5%); middle value at least 21-fold (1.33 log units) from the limit.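

In the Homo sapiens assay, the group of 12 heavy atoms with its six-membered non-aromatic ring with 1 hetero atom, in place of the group of 10 heavy atoms with its six-membered aromatic ring of carbon only, on an oxygen on a saturated carbon, gives an at least 23-fold higher number from compound 1 to compound 3 (1.37 log units; beyond the scatter), the first step read at this position, and it shows that the half-life responds strongly to this change. In a physicochemical assay for metabolic stability, read by HPLC, tested at 2 mM (a lower number here means that the compound disappears faster, a higher number that the compound lasts longer), compound 1 gives 6.6 h. In the physicochemical assay compound 3 gives > 120 h, which is a limit of the assay and not a number. The same change also stands out in the physicochemical assay: the measured half-life of compound 1, 6.6 h, and of compound 3, > 120 h, an at least 18-fold higher number (1.25 log units; beyond the scatter) The step therefore does not rest on a single read-out, and in both assays it lies beyond the scatter.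

As far as these compounds go, compound 3 sits at a limit of the assay, not at a number, in the Homo sapiens assay and in the physicochemical assay, so the full size of the step stays open in both. Also open, from the compounds shown here alone, is whether the step follows the non-aromatic ring or its nitrogen, which a cyclohexyl ring or an open-chain amine on this oxygen would help to separate.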